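This account rests on a few compounds, and the source may have more. Where it says the series, first, only, none or still open, it means among the compounds named here.

Working notes on the series

Of the compounds shown here, three have been measured in an assay on cell membranes for displacement of a labelled ligand from Neuronal acetylcholine receptor; alpha4/beta2 (Rattus norvegicus); on this read-out higher numbers stand for weaker inhibition and lower numbers for stronger inhibition. Compound 1 `c1ccc(Nc2ccc(N3CC4CC(C3)N4)cn2)cc1` gives 2.66 nM in this assay. Compound 2 `FC(F)(F)c1ccc(Nc2ccc(N3CC4CC(C3)N4)cn2)cc1` gives 0.569 nM. Compound 3 `FC(F)(F)c1ccc(Nc2cncc(N3CC4CC(C3)N4)c2)cc1` gives 0.373 nM.

Compound 2 and compound 1 share a core and differ in one place: hydrogen in place of trifluoromethyl on an aromatic carbon. That change gave a 4.7-fold higher number from compound 2 to compound 1 (0.67 log units; beyond the scatter). Compound 3 and compound 2 are built from the same atoms joined differently; the difference between the two cores is not broken down here. The values of compound 2 and compound 3 lie within the usual scatter of each other, while compound 1 sits beyond the scatter from compound 3.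

Compound 4 `c1ccc(Nc2cncc(N3CC4CC(C3)N4)c2)cc1` has not yet been measured in this assay. It relates to compound 3 as compound 1 relates to compound 2: hydrogen in place of trifluoromethyl on an aromatic carbon. The place lines for the two changes read the same, so this is the same change made on the core of compound 3 instead of the core of compound 2. Within the data shown here, the only measured precedent for the change is a 4.7-fold higher number from compound 2 to compound 1 (0.67 log units; beyond the scatter), and with a single example the change is expected to be of about the same size here. The estimated step is a 4.6-fold higher number from compound 3 to compound 4 (0.66 log units; beyond the scatter). On that basis compound 4 is expected to give 1.7 nM in this assay, with a range from 0.7 nM to 4.5 nM allowed for the uncertainty of a single precedent.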

Compound 4, inhibition constant: 0.0807 nM
Compound 4: the middle estimate sits 21-fold (1.32 log units) above what was measured; measured number outside the range, below it.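

In this assay, hydrogen in place of trifluoromethyl gave a 4.6-fold lower number from compound 3 to compound 4 (0.66 log units; beyond the scatter), so the change did not carry over from one core to the other in either direction or outcome, even though its size is similar on the two cores: the same change on two cores in this assay, a 4.7-fold higher number (0.67 log units; beyond the scatter) from compound 2 to compound 1 and a 4.6-fold lower number (0.66 log units; beyond the scatter) from compound 3 to compound 4, 22-fold (1.33 log units) apart, beyond the scatter of two such steps

For this pair of cores, a step measured on one is therefore no guide to the same change on the other, and the sign of the step has to be established separately on each core. What this does not show is the reason the two cores part, or how the change would behave on any third core, since two matched pairs give only the fact of the reversal and no account of it.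

Open, on these data alone, is how a chlorine, a methoxy group or an amine on the same aromatic carbon would read on each of the two cores, and whether the opposite trend between the cores would persist across such groups or is confined to hydrogen and trifluoromethyl. Also open, as far as these compounds go, is whether the same reversal would appear on any receptor other than the one read here.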